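Swapping a butoxy chain for cyclohexyl on the shared core

The source may hold more compounds than are shown below. What is called first, only, known or untested is meant among the compounds shown, and "the series" means these compounds.

Compound 3 `CCCCOc1cc(C(C)(C)C)ccc1CNC(=O)C(C)c1ccc(NS(C)(=O)=O)c(F)c1` gives the lowest number of three in an assay on cells for antagonist activity at transient receptor potential cation channel subfamily V member 1 (Homo sapiens), read by FLIPR and calcium flux, with a stated time of 6 min (on this read-out lower numbers stand for stronger inhibition and higher numbers for weaker inhibition), at 1.4 nM. Compound 1 `CCCCSc1nc(C(C)(C)C)ccc1CNC(=O)C(C)c1ccc(NS(C)(=O)=O)c(F)c1` gives 3.2 nM and compound 2 `CCCCCSc1nc(C(C)(C)C)ccc1CNC(=O)C(C)c1ccc(NS(C)(=O)=O)c(F)c1` gives 3.1 nM in this assay. Within the data shown here, the only single-site step seen so far, a 1.0-fold lower number from compound 1 to compound 2 (0.01 log units; within the scatter), lengthens a chain and changes nothing beyond the scatter. Among the measured compounds shown here, compound 4 `CC(C(=O)NCc1ccc(C(C)(C)C)cc1C1CCCCC1)c1ccc(NS(C)(=O)=O)c(F)c1` differs from compound 3 by cyclohexyl in place of butoxy on an aromatic carbon, a change for which no measured step gives direct guidance, so a modest shift is expected with wide uncertainty. Compound 4 is therefore estimated at 3 nM, with a range from 0.8 nM to 12 nM, the expected step being a 2.1-fold higher number from compound 3 to compound 4 (0.33 log units; beyond the scatter).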

Compound 4, inhibition constant: 9.8 nM
Compound 4: the middle estimate sits 3.3-fold (0.51 log units) below what was measured; measured number inside the range.
By their numbers in this assay, from the lowest: compound 3; then compounds 2 and 1 (each within the scatter of the next); then compound 4.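

In this assay, the aromatic carbon carrying butoxy proves sensitive to what stands on it: cyclohexyl in place of butoxy gives a 7.0-fold higher number from compound 3 to compound 4 (0.85 log units; beyond the scatter), the only single-place change shown that goes beyond the scatter. Lengthening the chain on sulfur, by contrast, gave just a 1.0-fold lower number from compound 1 to compound 2 (0.01 log units; within the scatter). Nothing available explains the shift at this position.

Going by these compounds, whether ethoxy, cyclopentyl or phenyl on this carbon would stay closer to compound 3 remains open. So does whether cyclohexyl would give a similar step on the core of compound 1.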